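Replacing an amide link by a benzyl link on a shared core

The source may hold more compounds than are shown below. What is called first, only, known or untested is meant among the compounds shown, and "the series" means these compounds.

The compounds here are partial agonists that all carry the same core, seen in compound 1 `CC(C)c1onc(-c2c(Cl)cccc2Cl)c1COc1ccc(N(C)C(=O)c2ccc(C(=O)O)cc2)c(C(F)(F)F)n1`, compound 2 `Cc1cc(OCc2c(-c3c(Cl)cccc3Cl)noc2C(C)C)nc2ccccc12` and compound 3 `Cc1cc(C(F)(F)F)cc(OCc2c(-c3c(Cl)cccc3Cl)noc2C(C)C)n1`. In a functional assay on HEK293 cells for agonist activity at Bile acid receptor (Homo sapiens), read by a luciferase reporter (a lower number here means a smaller maximal response, a higher number a larger maximal response), compound 1 gives 63%. In this assay compound 2 gives 68%, a value that lies within the usual scatter of that of compound 1, so the two cannot be told apart. Compound 3 is reported in this assay as "not active" (no number reported), and no number is given for it.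

Compound 4 `CC(C)c1onc(-c2c(Cl)cccc2Cl)c1COc1ccc(N(C)Cc2cccc(C(=O)O)c2)c(C(F)(F)F)n1` has not yet been measured. It differs from compound 1 in one place: 3-carboxybenzyl in place of (4-carboxyphenyl)carbonyl on a nitrogen on an aromatic ring. Put simply, the carbonyl that joins the carboxyphenyl group to the ring nitrogen is removed, and the carboxylic acid moves to another position of the phenyl ring.

Going by the values given here, no pair of measured compounds that differ in a single place is available, so the size of this step is not anchored by data. The two numbered compounds sit close together, and compound 3 shows that small changes on this core can abolish the response. The step from compound 1 to compound 4 is expected to be a number 11 percentage points lower from compound 1 to compound 4 (beyond the scatter), a modest loss that may well stay inside the scatter. Compound 4 is therefore estimated to reach 52%, with a plausible range from 25% to 78%.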

Compound 4, largest response reached (reported as efficacy), in percent of the reference or control that the assay uses: 58%
Beside the measured number, compound 4's estimate is 6 percentage points below it; the measured number falls inside the stated range.
By their numbers in this assay, from the lowest: compounds 4, 1 and 2 (each within the scatter of the next).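

Putting 3-carboxybenzyl in place of (4-carboxyphenyl)carbonyl on this nitrogen gives, in this assay, a number 5 percentage points lower from compound 1 to compound 4 (within the scatter), so compound 1 and compound 4 cannot be told apart. Going by these compounds alone, this is the first direct comparison at this position, and it shows that the partial response survives when the carbonyl is removed and the carboxylic acid moves on the phenyl ring, both in a single step. No measurement here bears on why the response holds across this change.

The two parts of the change stay tangled, so the compounds shown leave open what removing the carbonyl alone would do and what moving the carboxylic acid alone would do. Also open, on these data alone, is what would happen to the response in this assay if an amine took the place of the carboxylic acid, or if a longer chain such as 2-phenylethyl took the place of the benzyl group.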